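Swapping the Ring on the Side Chain of Compound 3

A few compounds are considered here, and "the series" means these few. Any claim that something is new, unique, unknown or untested is made for them only; others in the source may bear on it.

Of the compounds shown here, three sharing one core have been measured in an ADME assay on microsomes from liver (Rattus norvegicus) for metabolic stability; on this read-out lower numbers stand for a shorter-lived compound and higher numbers for a longer-lived compound. Compound 1, `CC(C)C(c1nnc[nH]1)c1ccc(-c2ccc3cccc(F)c3c2)[nH]c1=O`, gives 0.552 h. Compound 2, `CC(C)C(Nc1nccs1)c1ccc(-c2ccc3cccc(F)c3c2)[nH]c1=O`, gives 0.07 h. Compound 3, `CC(C)C(c1noc(=O)[nH]1)c1ccc(-c2ccc3cccc(F)c3c2)[nH]c1=O`, reaches only a limit, > 3 h, so its true number is not known; this is the limit of > 3 h in this assay, at which 1 of the 3 values shown sits. The step of an at least 5.4-fold higher number from compound 1 to compound 3 (0.73 log units; beyond the scatter) and the step of an at least 42-fold higher number from compound 2 to compound 3 (1.63 log units; beyond the scatter) show that changes at this one spot move the half-life strongly, and that compound 3 stands highest of the three.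

Compound 4, `CC(C)C(/C=C1/CCNC1=O)c1ccc(-c2ccc3cccc(F)c3c2)[nH]c1=O`, differs from compound 3 at the same spot: a group of 7 heavy atoms (5 carbon, 1 nitrogen, 1 oxygen; one five-membered non-aromatic ring with 1 hetero atom) in place of a group of 6 heavy atoms (2 carbon, 2 nitrogen, 2 oxygen; one five-membered aromatic ring with 3 hetero atoms), on a saturated chain carbon bound to an aromatic carbon and a saturated chain carbon. Within the data shown here, no measured step shows this particular swap, yet both steps leading into compound 3 were large, and compound 4 gives up the ring that carried the highest number. A lower number is therefore expected, most likely a sizeable drop, although the limit on compound 3 leaves the size of that drop uncertain. The estimated step from compound 3 to compound 4 is an at least 6.0-fold lower number from compound 3 to compound 4 (0.77 log units; beyond the scatter). Compound 4 is expected to come out at 0.5 h, within a range of 0.1 h to 2.5 h.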

Compound 4, half-life: 0.06 h
Beside the measured number, compound 4's estimate is 8.3-fold (0.92 log units) above it; measured number below the stated range.
By their numbers in this assay, from the lowest: compounds 4 and 2 (each within the scatter of the next); then compound 1. At a limit, above all of these: compound 3.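

In this assay, replacing the five-membered aromatic ring with 3 hetero atoms by the five-membered non-aromatic ring with 1 hetero atom gives an at least 50-fold lower number from compound 3 to compound 4 (1.69 log units; beyond the scatter), so a new group at this one place can remove nearly all of the half-life seen for compound 3. As far as these compounds go, the true size of that step stays unknown, as compound 3 carries a limit and not a number: the limit of > 3 h in this assay, at which 1 of the 4 values shown sits. The new group also gives a 9.2-fold lower number from compound 1 to compound 4 (0.96 log units; beyond the scatter), while a 1.2-fold lower number from compound 2 to compound 4 (0.07 log units; within the scatter) means that these two compounds cannot be told apart, so a short half-life here is not tied to one kind of group: a non-aromatic ring and a (1,3-thiazol-2-yl)amino group both give it.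

The compounds shown do not reveal which feature of the ring in compound 3 goes with the long half-life, or which part of the molecule is lost quickly in compound 2 and compound 4. A carboxylic acid or a tetrazole on the same saturated chain carbon would show whether a long half-life is special to that ring or shared by other groups.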